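A few compounds are considered here, and "the series" means these few. Any claim that something is new, unique, unknown or untested is made for them only; others in the source may bear on it.

Compound 3, `Nc1scc(CN2CCN(c3ccc(OC(F)(F)F)cc3)CC2)c1C(=O)c1ccc(Cl)cc1`, is one of three close analogues that share a core and differ only in the aryl group on an amine nitrogen in a ring. In a functional assay on CHO cells with adenosine receptor A1 (Homo sapiens) as the target, read by cAMP accumulation and immunoassay, with a stated time of 6 min, tested at 0.01 uM (a lower number here means a stronger effect, a higher number a weaker effect of the compound at the concentration tested), compound 3 gives 0%, the highest of the three numbers. Compound 1, `Nc1scc(CN2CCN(c3ccc(Cl)cc3F)CC2)c1C(=O)c1ccc(Cl)cc1`, gives -9.2% in this assay, and compound 2, `Nc1scc(CN2CCN(c3ccc([N+](=O)[O-])cc3)CC2)c1C(=O)c1ccc(Cl)cc1`, gives -12%; the steps were a number 9.2 percentage points higher from compound 1 to compound 3 (within the scatter) and a number 12 percentage points higher from compound 2 to compound 3 (beyond the scatter). Compound 4, `Nc1scc(CN2CCN(c3ccncc3)CC2)c1C(=O)c1ccc(Cl)cc1`, differs from compound 3 as follows: pyridin-4-yl in place of 4-(trifluoromethoxy)phenyl on an amine nitrogen in a ring. Both earlier changes at this same position moved the number little, so for compound 4 a step no larger than the scatter is expected, namely a number 3 percentage points lower from compound 3 to compound 4 (within the scatter). Compound 4 is therefore estimated at -3%, within a range from -15% to 10%.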

Compound 4, a percentage reported as activity, at one concentration (the size of the read-out at that concentration, not a potency): -4%
The estimate for compound 4 lay 1 percentage points above the measured number; the range from low to high includes it.
By their numbers in this assay, from the lowest: compounds 2, 1, 4 and 3 (each within the scatter of the next, the first and the last beyond it).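

Pyridin-4-yl is the only group here with a hetero atom in its aromatic ring, and it brings fewer heavy atoms than 4-(trifluoromethoxy)phenyl. Yet in this assay every new step stays within the scatter: a number 4 percentage points lower from compound 3 to compound 4 (within the scatter), a number 8 percentage points higher from compound 2 to compound 4 (within the scatter) and a number 5.2 percentage points higher from compound 1 to compound 4 (within the scatter). So at this position, neither the hetero atom nor the smaller group produces a step that can be told from the scatter, and nothing available explains this. From the compounds shown here alone, whether a benzyl group or a plain ethyl chain on this amine nitrogen would also stay within the scatter remains open.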